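Nitro to nitrile swap on two amide cores

The compounds below may be only part of what the source reports. "The series", "measured", "known", "first", "only" and "open" are said of these compounds alone.

Compound 1 `O=C(Nc1ccc([N+](=O)[O-])cc1Cl)c1cc(-c2ccc(F)cc2F)ccc1O`: < 1 ug/mL
Compound 2 `O=C(Nc1ccc([N+](=O)[O-])cc1Cl)c1cccc2cc[nH]c12`: < 1 ug/mL
Compound 3 `N#Cc1ccc(NC(=O)c2cc(-c3ccc(F)cc3F)ccc2O)c(Cl)c1`: < 1 ug/mL

In a physicochemical assay for solubility (on this read-out higher numbers stand for higher solubility and lower numbers for lower solubility), compound 1 gives < 1 ug/mL, which is a limit of the assay rather than a number. Compound 3 gives < 1 ug/mL, again a limit. Compound 2 gives < 1 ug/mL, also a limit. Compound 3 arises from compound 1 through (cyano in place of nitro on an aromatic carbon). The resulting step that the two limits leave unreadable from compound 1 to compound 3 stays unreadable because of the limit of < 1 ug/mL in this assay, at which 3 of the 3 values shown sit. How the core of compound 2 differs from the core of compound 1 is not broken down here.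

Compound 4 `N#Cc1ccc(NC(=O)c2cccc3cc[nH]c23)c(Cl)c1` has not yet been measured in this assay. It arises from compound 2 through (cyano in place of nitro on an aromatic carbon), the same change as that from compound 1 to compound 3. The step from compound 2 to compound 4 is expected to be about a step that the limit leaves unreadable from compound 2 to compound 4, unreadable in the same way, which rests on (the limit of < 1 ug/mL in this assay, at which 3 of the 3 values shown sit). Compound 4 is therefore estimated at 0.5 ug/mL, with a likely range from 0.1 ug/mL to 3 ug/mL, and most probably the assay will again report only a limit.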

Compound 4, solubility: < 1 ug/mL
Compound 4 was reported as a limit (the forecaster's own chance of this, stated with the estimate: 75%); the middle value lies beyond the limit too.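

Compound 2 and compound 4 both sit at the limit, so no step can be read between them, and the same holds for compound 1 and compound 3: the limit of < 1 ug/mL in this assay, at which 4 of the 4 values shown sit.

The compounds shown leave open whether cyano in place of nitro shifts the read-out of this assay on either core, and how far each compound lies from that limit.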